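A few compounds are considered here, and "the series" means these few. Any claim that something is new, unique, unknown or untested is made for them only; others in the source may bear on it.

Compound 1 `CCCNS(=O)(=O)c1ccc(Nc2ncc3c(n2)N(C2CCCC2)[C@H](CC)C(=O)N3C)cc1` gives 459 nM in a functional assay on HeLa cells (Homo sapiens) for antiproliferative activity, read by CCK-8 assay, with a stated time of 72 h (a higher number here means a weaker inhibitor of growth, a lower number a stronger inhibitor of growth), the lower of the two numbers recorded so far. Compound 2 `CCC1C(=O)N(C)c2cnc(-n3ccc4cc(C(N)=O)ccc43)nc2N1c1ccn(C)n1` gives 27400 nM in this assay, and the gap between compound 1 and compound 2 lies beyond the scatter. Compound 3 `CC[C@@H]1C(=O)N(C)c2cnc(Nc3ccc(S(=O)(=O)NC4CCCC4)cc3)nc2N1C1CCCC1` has not yet been measured; it differs from compound 1 in one place: cyclopentyl in place of propyl on a sulfonamide nitrogen. Among the measured compounds shown here, no measured pair carrying this change is available, so the expected step of a 1.2-fold lower number from compound 1 to compound 3 (0.08 log units; within the scatter) is small and within the scatter, with no clear direction. Compound 3 is therefore expected to give about 380 nM in this assay, estimated between 130 nM and 1200 nM.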

Compound 3, concentration for 50% growth inhibition: 609 nM
Beside the measured number, compound 3's estimate is 1.6-fold (0.20 log units) below it; measured number inside the range.
By their numbers in this assay, from the lowest: compounds 1 and 3 (each within the scatter of the next); then compound 2.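

On the sulfonamide nitrogen, cyclopentyl in place of propyl gives a 1.3-fold higher number from compound 1 to compound 3 (0.12 log units; within the scatter) in this assay. For this pair, then, a five-membered carbon ring and an open propyl chain cannot be told apart in this read-out, so closing the substituent into a ring has no resolvable effect here. No evidence on record bears on this result.

From the compounds shown here alone, both substituents contain carbon only, so it remains open how an amine, a hydroxyl or a carboxylic acid on this nitrogen would read. Going by these compounds, a phenyl ring or a longer chain at this position also remains untested in these compounds.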